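Swapping Methyl for Nitro on the Shared Core

The source may hold more compounds than are shown below. What is called first, only, known or untested is meant among the compounds shown, and "the series" means these compounds.

Compound 3 `Cc1ccc(NC(=S)OCCc2ccccc2)cc1` carries a methyl on its six-membered aromatic ring of carbon only. In an ADME assay on MT4 cells (Homo sapiens) for cytotoxicity, read by MTT assay (a higher number here means that more compound is tolerated, a lower number that less compound is tolerated), compound 3 gives > 100000 nM, which is a limit of the assay and not a number. In this assay compound 1 `Cc1ccc(NC(=S)OCCc2ccccn2)cc1` gives 75000 nM. In this assay compound 2 `CCc1ccc(NC(=S)OCCc2ccccn2)cc1` gives 44000 nM. The measured steps run a 1.7-fold lower number from compound 1 to compound 2 (0.23 log units; within the scatter) and an at least 1.3-fold higher number from compound 1 to compound 3 (0.12 log units; that floor lies within the scatter); the second carries only a floor because compound 3 sits at the limit of > 100000 nM in this assay, at which 1 of the 3 values shown sits.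

Compound 4 `O=[N+]([O-])c1ccc(NC(=S)OCCc2ccccc2)cc1` differs from compound 3 by nitro in place of methyl on an aromatic carbon. Neither measured step touches that ring: one alters a saturated chain carbon, the other exchanges pyridin-2-yl for phenyl. Among the compounds with values here, no measured step speaks to this change, and both stayed within the scatter, so for compound 4 a step of a number no higher from compound 3 to compound 4 (the limit leaves the size open) in this assay is expected, neither clearly up nor down. Compound 4 is estimated at 100000 nM, with a range from 40000 nM to 250000 nM, and a fair chance that only a limit is reported again.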

Compound 4, half-maximal cytotoxic concentration: > 100000 nM
Compound 4: only a limit was reported; the forecaster's own chance of this, stated with the estimate: 50%; the middle value sits exactly at the limit.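

No step can be read from compound 3 to compound 4, because both compounds stand at a limit of the assay and not at a number: the limit of > 100000 nM in this assay, at which 2 of the 4 values shown sit.

The compounds shown leave open whether nitro in place of methyl on an aromatic carbon changes the number in this assay at all.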